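The source may report more compounds than this note shows. Statements on the series, on what has been measured and on what is new or still open speak of the compounds shown alone.

Of the compounds shown here, three from this series have been tested in a functional assay on MCF7 cells (Homo sapiens) for cytotoxicity, read by sulforhodamine B assay; a lower number here means a stronger inhibitor, a higher number a weaker inhibitor. Compound 1, with the structure `C=C1[C@@H](OC(C)=O)C[C@@H]2[C@](C)(CO[Si](C)(C)C(C)(C)C)[C@H](OC(C)=O)CC[C@@]2(C)[C@@H]1C[C@@H](Nc1ccccc1)C1=CCOC1=O`, gives 4840 nM. Compound 3, `C=C1CC[C@@H]2[C@](C)(CO[Si](C)(C)C(C)(C)C)[C@H](OC(C)=O)CC[C@@]2(C)[C@@H]1C/C=C1/C(=O)OC[C@H]1OC(C)=O`, lacks the anilino group of compound 1. In this assay compound 3 gives 4840 nM, and the two values sit level at the digits shown, so the difference between them lies within the usual scatter of this assay. Compound 2, `C=C1[C@@H](OC(C)=O)C[C@@H]2[C@](C)(COC=O)[C@H](OC(C)=O)CC[C@@]2(C)[C@@H]1C[C@@H](Nc1ccc(OC)c(OC)c1)C1=CCOC1=O`, carries a different group on the aromatic ring and a different group at the side chain, and for it compound 2 returns only > 50000 nM, which is a limit of the assay rather than a number; it marks (the limit of > 50000 nM in this assay, at which 1 of the 3 values shown sits).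

The step to follow goes from compound 1 to the not yet measured compound 4, `C=C1[C@@H](OC(C)=O)C[C@@H]2[C@](C)(CO[Si](C)(C)C(C)(C)C)[C@H](OC(C)=O)CC[C@@]2(C)[C@@H]1C[C@@H](Nc1ccc(C(=O)O)cc1)C1=CCOC1=O`. The change is small on paper: carboxy in place of hydrogen on an aromatic carbon. For the measured compounds named here, no measured pair in this set reports that same change, so the expectation rests on the values of compound 1 and compound 3 alone and on the fact that one compound already sits at the limit. The step from compound 1 to compound 4 is expected to be a 1.9-fold higher number from compound 1 to compound 4 (0.27 log units; within the scatter), most likely a modest weakening, though a result inside the scatter would not surprise. Compound 4 is therefore estimated at 9000 nM, with a range from 2500 nM to 35000 nM.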

Compound 4, half-maximal inhibitory concentration: 3990 nM
The estimate for compound 4 lay 2.3-fold (0.35 log units) above the measured number, within the range that was stated.
By their numbers in this assay, from the lowest: compounds 4, 1 and 3 (each within the scatter of the next). At a limit, above all of these: compound 2.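

Putting a carboxy group in place of hydrogen on the anilino ring gives a 1.2-fold lower number from compound 1 to compound 4 (0.08 log units; within the scatter) in this assay, so the move from phenyl to 4-carboxyphenyl leaves a result that cannot be told apart from the scatter. For the compounds shown here, no earlier pair differed in one place only, which makes this the first single change that can be read directly, and at this position of the ring it shifts the number by no more than repeat measurements would. Nothing measured here explains why the number holds steady after this change.

The compounds shown leave open whether a nitrile or a methyl ester on the same ring carbon, or a carboxylic acid on another carbon of that ring, would also leave the number in this assay within the scatter. Compound 2 gives > 50000 nM in that assay, which is a limit and not a number, and it differs from compound 1 in more than one place, so it cannot show what any single group on this ring does.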